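A few compounds are considered here, and "the series" means these few. Any claim that something is new, unique, unknown or untested is made for them only; others in the source may bear on it.

Measured so far in a functional assay on PC-3 cells (Homo sapiens) for cytotoxicity, read by MTT assay, with a stated time of 72 h; a lower number here means a stronger inhibitor, a higher number a weaker inhibitor:
compound 1, `COc1ccc(C(=O)c2cc(OC)c(OC)c(OC)c2)cc1NC(=O)/C=C/c1cc(OC)c(OC)c(OC)c1`, 3900 nM
compound 2, `COc1ccc(C(=O)c2cc(OC)c(OC)c(OC)c2)cc1NC(=O)/C=C/c1ccc(OC)c(OC)c1`, 7500 nM
compound 3, `C#CCOc1cccc(/C=C/C(=O)Nc2cc(C(=O)c3cc(OC)c(OC)c(OC)c3)ccc2OC)c1`, 13100 nM

Compound 3 gives the highest number of the three. Its distance from compound 2 is a 1.7-fold higher number from compound 2 to compound 3 (0.24 log units; within the scatter), within the scatter, whereas its distance from compound 1, a 3.4-fold higher number from compound 1 to compound 3 (0.53 log units; beyond the scatter), goes beyond it. The remaining step, a 1.9-fold higher number from compound 1 to compound 2 (0.28 log units; within the scatter), stays within the scatter.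

Compound 4, `COc1cc(/C=C/C(=O)Nc2cc(C(=O)c3cc(OC)c(OC)c(OC)c3)ccc2OC)ccc1F`, is obtained from compound 3 by 4-fluoro-3-methoxyphenyl in place of 3-(propargyloxy)phenyl on a double-bonded chain carbon bound to a double-bonded chain carbon. For the measured compounds named here, the steps that bear on this change run in the opposite direction: a 3.4-fold higher number from compound 1 to compound 3 (0.53 log units; beyond the scatter) and a 1.7-fold higher number from compound 2 to compound 3 (0.24 log units; within the scatter) both raised the number when a methoxy-bearing phenyl gave way to the propargyloxy one. Compound 4 carries a single methoxy group together with a fluorine, which puts it nearer the situation of compound 2 than of compound 1, so the reverse of a 1.7-fold higher number from compound 2 to compound 3 (0.24 log units; within the scatter) is the closer guide. In this assay a somewhat lower number than that of compound 3 is therefore expected, though the step may not clear the scatter. For compound 4 the estimate is 7000 nM, with a range of 3000 nM to 16000 nM. This corresponds to an expected step of a 1.9-fold lower number from compound 3 to compound 4 (0.27 log units; within the scatter).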

Compound 4, half-maximal inhibitory concentration: 14100 nM
The estimate for compound 4 lay 2.0-fold (0.30 log units) below the measured number, within the range that was stated.
By their numbers in this assay, from the lowest: compounds 1, 2, 3 and 4 (each within the scatter of the next, the first and the last beyond it).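

In this assay, 4-fluoro-3-methoxyphenyl in place of 3-(propargyloxy)phenyl on a double-bonded chain carbon bound to a double-bonded chain carbon gives a 1.1-fold higher number from compound 3 to compound 4 (0.03 log units; within the scatter) and so leaves no resolvable change, despite the loss of the triple bond. Fluoro in place of methoxy on an aromatic carbon is likewise unresolved, with a 1.9-fold higher number from compound 2 to compound 4 (0.27 log units; within the scatter) as its step, whereas a 3.6-fold higher number from compound 1 to compound 4 (0.56 log units; beyond the scatter) is a modest separation from the 3,4,5-trimethoxyphenyl compound, matching the separation already seen for the propargyloxy compound. No measurement is available to explain these readings.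

As far as these compounds go, it remains open whether an amine or a hydroxyl group in place of the fluoro would give a step beyond the scatter. Also unsettled is whether any replacement for the 3,4,5-trimethoxyphenyl group can match it in this assay and still carry a longer chain.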